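Carbamoyl to carboxy on the compound 1 side chain

The compounds below may be only part of what the source reports. "The series", "measured", "known", "first", "only" and "open" are said of these compounds alone.

In a physicochemical assay for lipophilicity, read by HPLC, at pH 7.5 (a higher number here means a more lipophilic compound, a lower number a more polar compound), compound 1 `CC[C@@H](Nc1c(C#N)c(-c2ccc(-c3cccc(Cl)c3F)cc2)nc2cnccc12)C(N)=O` gives 3.1, the higher of the two numbers, and compound 2 `CC[C@@H](Nc1c(C#N)c(-c2ccc(-c3ccc(OC)cc3)cc2)nc2cnccc12)C(N)=O` gives 2.7. Compound 3 `CC[C@@H](Nc1c(C#N)c(-c2ccc(-c3cccc(Cl)c3F)cc2)nc2cnccc12)C(=O)O` differs from compound 1 by hydroxy in place of amino on a carbonyl carbon, with hydroxy in place of amino on a carbonyl carbon. Going by the values given here, the only measured step, a number 0.40 log units lower from compound 1 to compound 2 (beyond the scatter), is modest and concerns a change on an aromatic carbon, so it offers a scale but no direct precedent. A lower number is expected, with an estimated change larger than that measured step: a number 1.50 log units lower from compound 1 to compound 3 (beyond the scatter). Compound 3 is expected at 1.6, with an estimated range of 0.8 to 2.4.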

Compound 3, distribution coefficient: 2.2
Compound 3: the middle estimate sits 0.60 log units below what was measured; low and high end bracket the measured number.
By their numbers in this assay, from the lowest: compound 3; then compound 2; then compound 1.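

Replacing amino with hydroxy on the carbonyl carbon of the side chain gives in this assay a number 0.90 log units lower from compound 1 to compound 3 (beyond the scatter) and so shows that this position also moves the read-out, whereas the earlier step concerned only a change on an aromatic carbon. Nothing available gives a measured reason for this step. Still open, on these data alone, is how a methyl ester or a primary alcohol in place of carboxy would read at this position. Also open, as far as these compounds go, is whether the same change on compound 2 would give a similar step.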